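The compounds below may be only part of what the source reports. "The series", "measured", "known", "first", "only" and "open" are said of these compounds alone.

In an ADME assay on HaCaT cells (Homo sapiens) for inhibition, read by sulforhodamine B assay, with a stated time of 48 h (on this read-out lower numbers stand for stronger inhibition of growth and higher numbers for weaker inhibition of growth), compound 1 `CCOC(=O)c1nn(-c2ccccc2)c(-c2ccc(Cl)cc2)c1CNC(C)(C)C` gives 63500 nM; > 559000 nM (2 entries). Compound 2 `CC(C)(C)NCc1c(C(=O)O)nn(-c2ccccc2)c1-c1ccc(F)cc1` has no single number in this assay. Going by the values given here, its only entry with a value is compound 2 at > 680000 nM, which is a limit of the assay.

Compound 3 `CC(C)(C)NCc1c(C(=O)O)nn(-c2ccccc2)c1-c1ccc(Cl)cc1` has not yet been measured and differs from compound 2 at one place: chloro in place of fluoro on an aromatic carbon. The change sits para to a large group, so that 4-fluorophenyl becomes 4-chlorophenyl. Among the compounds with values here, no measured pair in this small set isolates that change, so the data give no direct size for it.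

No step beyond the usual scatter is expected in this assay, in either direction. That expectation rests on compound 2 at > 680000 nM, again a limit, and the assay may well report only a limit for compound 3. The estimated step is an at least 1.1-fold lower number from compound 2 to compound 3 (0.05 log units; that floor lies within the scatter). For compound 3 the estimated value is 600000 nM, with an expected range from 200000 nM to 1000000 nM.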

Compound 3, concentration for 50% growth inhibition: > 652000 nM
Compound 3: only a limit was reported (the forecaster's own chance of this, stated with the estimate: 75%); at least 1.0-fold (0.03 log units) between middle value and limit.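

In this assay, going by these compounds alone, compound 2 and compound 3 are both reported only as limits of the assay, and no step from one to the other can be read. The compounds shown leave open whether chloro in place of fluoro on an aromatic carbon changes growth inhibition at all: neither compound carries a single number here.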